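Removing one methyl from the dimethylphenyl sulfonamide

The source may hold more compounds than are shown below. What is called first, only, known or untested is meant among the compounds shown, and "the series" means these compounds.

Measured so far:
- compound 1 `Cc1noc(C)c1S(=O)(=O)N1CCC(N2CCC(C)CC2)CC1`: > 5000 nM
- compound 2 `CC1CCN(C2CCN(S(=O)(=O)c3cccc(-c4ccc(Cl)cc4)c3)CC2)CC1`: 15 nM
- compound 3 `Cc1ccc(S(=O)(=O)N2CCC(N3CCC(C)CC3)CC2)cc1C`: 24 nM

The series shares a piperidinyl-piperidine sulfonamide core and varies the aryl group on the sulfonyl sulfur. In a functional assay on DLD-1 cells (Homo sapiens) for antiproliferative activity, read by CellTiter-Glo, with a stated time of 72 h (a lower number here means a stronger inhibitor, a higher number a weaker inhibitor), compound 3 gives 24 nM. Of the two numbers shown it is the higher one, but the nearest neighbour, compound 2 with 15 nM in this assay, lies within the scatter, so the two are not separated. For compound 1 the result in this assay is only a limit, > 5000 nM (the limit of > 5000 nM in this assay, at which 1 of the 3 values shown sits). Going by the values given here, the one measured step, an at least 200-fold lower number from compound 1 to compound 3 (2.31 log units; beyond the scatter), is large, but it concerns an exchange of the whole aryl group and says little about a single methyl.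

Compound 4 `Cc1cccc(S(=O)(=O)N2CCC(N3CCC(C)CC3)CC2)c1` has not yet been measured. It differs from compound 3 by hydrogen in place of methyl on an aromatic carbon. Among the compounds with values here, no measured step covers this change, so the expected step of a 1.5-fold higher number from compound 3 to compound 4 (0.16 log units; within the scatter) is small and within the scatter, with at most a slight weakening. Compound 4 is therefore estimated at 35 nM in this assay, with a range of 12 nM to 110 nM.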

Compound 4, half-maximal inhibitory concentration: 25 nM
Compound 4: the middle estimate sits 1.4-fold (0.15 log units) above what was measured; low and high end bracket the measured number.
By their numbers in this assay, from the lowest: compounds 2, 3 and 4 (each within the scatter of the next). At a limit, above all of these: compound 1.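

Within the 3,4-dimethylphenyl to 3-methylphenyl change, the methyl ortho to a methyl group and para to a large group can leave without a readable effect (a 1.0-fold higher number from compound 3 to compound 4 (0.02 log units; within the scatter)) in this assay, and a single methyl on this ring is not separated from the larger 4-chlorophenyl (a 1.7-fold higher number from compound 2 to compound 4 (0.22 log units; within the scatter)). One methyl on the phenyl ring is thus enough to keep the large gap to the dimethyl-oxazole sulfonamide (an at least 200-fold lower number from compound 1 to compound 4 (2.30 log units; beyond the scatter)). The number for compound 1 is a limit: the limit of > 5000 nM in this assay, at which 1 of the 4 values shown sits.

Open is whether the remaining methyl matters, since a plain phenyl without any methyl is not among the compounds shown. Also open, going by these compounds, is how this place on the ring responds to a group such as an amine or a carboxylic acid.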